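From Butyl to Benzylsulfanyl at One Aromatic Carbon

This account rests on a few compounds, and the source may have more. Where it says the series, first, only, none or still open, it means among the compounds named here.

Compound 1 `Nc1nc(O)nc2c1nc(O)n2Cc1ccccc1`: 0.1 uM
Compound 2 `CCCSc1nc(N)c2nc(O)n(Cc3ccccc3)c2n1`: 0.01 uM
Compound 3 `CCCCc1nc(N)c2nc(O)n(Cc3ccccc3)c2n1`: 0.03 uM

Of the compounds shown here, three sharing one core have been measured in a functional assay (spleen, spleen) for activation, with Mus musculus as the target; a lower number here means that less compound is needed, a higher number that more compound is needed for the effect. Compound 3 stands second highest of the three numbers: its nearest neighbour is compound 2, the step of a 3.0-fold higher number from compound 2 to compound 3 (0.48 log units; beyond the scatter) having been recorded, while against compound 1 the step of a 3.3-fold lower number from compound 1 to compound 3 (0.52 log units; beyond the scatter) sets it apart in the other direction.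

Compound 4 `Nc1nc(SCc2ccccc2)nc2c1nc(O)n2Cc1ccccc1` is the next compound in this line. Its difference from compound 3 is benzylsulfanyl in place of butyl on an aromatic carbon. Within the data shown here, two measured steps bear on this change. The step of a 10-fold lower number from compound 1 to compound 2 (1.00 log units; beyond the scatter) shows that a sulfanyl group at this carbon gave the lowest number of the set, and the step of a 3.0-fold higher number from compound 2 to compound 3 (0.48 log units; beyond the scatter) shows that replacing that sulfanyl group by butyl raised the number. Compound 4 carries a sulfanyl group again, now with a benzyl on it, so the number is expected to move back toward that of compound 2; a modest step of a 2.0-fold lower number from compound 3 to compound 4 (0.30 log units; within the scatter) is expected for compound 4. Compound 4 is therefore estimated at 0.015 uM, within a range from 0.003 uM to 0.06 uM.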

Compound 4, minimum effective concentration: 0.1 uM
Compound 4: the middle estimate sits 6.7-fold (0.82 log units) below what was measured; measured number above the stated range.
By their numbers in this assay, from the lowest: compound 2; then compound 3; then compounds 1 and 4 (each within the scatter of the next).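

In this assay, the sulfur at this aromatic carbon does not by itself bring the low number, since phenyl in place of ethyl on the saturated chain carbon bound to that sulfur gives a 10-fold higher number from compound 2 to compound 4 (1.00 log units; beyond the scatter) and thus the largest rise among the new steps. Benzylsulfanyl also compares poorly with the all-carbon butyl chain, with a 3.3-fold higher number from compound 3 to compound 4 (0.52 log units; beyond the scatter) in this change, and it gains nothing over hydroxy, with no change at the digits printed from compound 1 to compound 4 (within the scatter) on that exchange, so the group carried on the sulfur matters at this position. Nothing measured here accounts for this difference.

On these data alone, it remains open how the number would respond to a methyl or a pentyl chain on the sulfur, or to a phenethyl group there. Also open, as far as these compounds go, is whether an amine at this aromatic carbon would follow the sulfanyl or the butyl compounds.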